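Does an aryl group change how well Huh-7 cells tolerate this series?

The source may report more compounds than this note shows. Statements on the series, on what has been measured and on what is new or still open speak of the compounds shown alone.

Measured in a functional assay on Huh-7 cells (Homo sapiens) for cytotoxicity, read by MTT assay, with a stated time of 72 h; a lower number here means that less compound is tolerated, a higher number that more compound is tolerated:
Compound 1 `CS(=O)(=O)N1CCC2(CC1)OOC1(CCCCC1)OO2`: > 100 ug/mL
Compound 2 `CCCS(=O)(=O)N1CCC2(CC1)OOC1(CCCC1)OO2`: > 100 ug/mL

Both values are limits of the assay, not numbers. Compound 2 stands at the limit of > 100 ug/mL in this assay, at which 2 of the 2 values shown sit. Compound 3 `COc1ccc(S(=O)(=O)N2CCC3(CC2)OOC2(CCCC2)OO3)cc1` carries 4-methoxyphenyl in place of propyl on a sulfonyl sulfur. Among the measured compounds shown here, no measured step shows what such a change does, so no shift beyond the scatter is expected in this assay, in either direction. The estimated change is a number no higher from compound 2 to compound 3 (the limit leaves the size open). Compound 3 is expected at 100 ug/mL, with an estimated range of 45 ug/mL to 220 ug/mL.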

Compound 3, half-maximal cytotoxic concentration: > 100 ug/mL
Compound 3: no number, only a limit; the forecaster's own chance of this, stated with the estimate: 60%; the middle value lies on the limit itself.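

Compound 2 and compound 3 give no readable step, because both values are limits and not numbers: the limit of > 100 ug/mL in this assay, at which 3 of the 3 values shown sit.

Going by these compounds, whether 4-methoxyphenyl in place of propyl changes how much compound is tolerated in this assay stays open.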